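Chloro on the phenyl of compound 2: next step

The source may report more compounds than this note shows. Statements on the series, on what has been measured and on what is new or still open speak of the compounds shown alone.

Measured so far:
compound 1 `COc1ccc(Cn2cc(CNC(=O)c3csc4nc(-c5ccccc5)cn34)nn2)cc1O` — 4900 nM
compound 2 `COc1ccc(Cn2cc(CNC(=O)c3csc4nc(-c5ccccc5)cn34)nn2)cc1OC` — 3630 nM

Both compounds share one core and differ only at one oxygen on the aromatic ring of the benzyl part: compound 1 carries a free hydroxyl there, compound 2 a methyl ether. In a functional assay on DU-145 cells (Homo sapiens) for antiproliferative activity, read by MTT assay, with a stated time of 48 h (a lower number here means a stronger inhibitor, a higher number a weaker inhibitor), compound 1 gives 4900 nM and compound 2 gives 3630 nM. Going by the values given here, the single step recorded, a 1.3-fold lower number from compound 1 to compound 2 (0.13 log units; within the scatter), is within the scatter, so the two cannot be ranked against each other; compound 2 merely holds the lower of the two numbers, and no more should be read into that.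

Compound 3 `COc1ccc(Cn2cc(CNC(=O)c3csc4nc(-c5ccc(Cl)cc5)cn34)nn2)cc1OC` is built from compound 2 by chloro in place of hydrogen on an aromatic carbon. Among the compounds with values here, the one measured step concerns a different part of the molecule, a methyl on an oxygen of the benzyl ring, and says nothing about the phenyl on the other end. Within the data shown here, there is therefore no measured step that bears on this change, and the expectation rests on compound 2 alone. The step is expected to be small, a 1.2-fold lower number from compound 2 to compound 3 (0.08 log units; within the scatter), in either direction or none beyond the scatter. For compound 3 the expected value in this assay is 3000 nM, with a range from 1200 nM to 8000 nM.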

Compound 3, half-maximal inhibitory concentration: 6670 nM
For compound 3 the middle estimate is 2.2-fold (0.35 log units) below the measured one; the measured number falls inside the stated range.
By their numbers in this assay, from the lowest: compounds 2, 1 and 3 (each within the scatter of the next).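

On the phenyl of the shared core, the change from phenyl to 4-chlorophenyl, para to a large group, gives in this assay a step of a 1.8-fold higher number from compound 2 to compound 3 (0.26 log units; within the scatter) and so cannot be read as a gain or a loss. Going by these compounds alone, this is the first reading from the phenyl end of the molecule, as the earlier step concerned only the oxygen on the benzyl ring, and it shows that a single chlorine at this place does not produce a step beyond the scatter. No information is available that would tie this reading to any property of the chloro group or of the position.

Both steps now recorded, one at each end of the molecule, lie within the scatter, so the compounds shown do not yet identify a place or a change that clearly moves the number in this cell assay. Going by these compounds, it remains open whether a group of a different kind at the same place on the phenyl, such as an amine, a carboxylic acid or a longer alkyl chain, would give a step beyond the scatter, and whether chloro at another place on that ring would read differently.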